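One More Methoxy on a Weakly Stable Compound

This account rests on a few compounds, and the source may have more. Where it says the series, first, only, none or still open, it means among the compounds named here.

Compound 1 `COc1nn2cc(-c3cc4c(OC)ccc(OC)c4o3)nc2s1`: 55%
Compound 2 `COc1cc(OCc2cccc(O)c2)c2cc(-c3cn4nc(OC)sc4n3)oc2c1`: 97%
Compound 3 `COc1nn2cc(-c3cc4c(OC)cccc4o3)nc2s1`: 40%

All three numbers come from an ADME assay on microsomes from liver (Homo sapiens) for metabolic stability, with a stated time of 10 min; on this read-out higher numbers stand for a more stable compound and lower numbers for a less stable compound. Compound 3 stands lowest of the three at 40%, clearly under compound 1 and far under compound 2, which reads 97%.

The next compound to be tested is compound 4 `COc1cc(OC)c2cc(-c3cn4nc(OC)sc4n3)oc2c1`. It carries methoxy in place of hydrogen on an aromatic carbon of a six-membered aromatic ring of carbon only, part of a fused or bridged system of two rings, (methoxy in place of hydrogen on an aromatic carbon). The new group sits meta to a methoxy group and para to a fused ring.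

Among the compounds with values here, only one measured step bears on this change. It is a number 15 percentage points lower from compound 1 to compound 3 (beyond the scatter), and it runs the opposite way, with hydrogen in place of methoxy. Read in reverse, it suggests a modest gain in this assay when a methoxy is added. Compound 1 and compound 4 hold their added methoxy in different places, however, so the guide is loose. Within the data shown here, compound 2 differs from compound 3 in more than one place and gives no step to draw on.

The step expected is a number 14 percentage points higher from compound 3 to compound 4 (beyond the scatter), upward and modest. For compound 4 the estimate is 54%, with an expected range of 34% to 76%.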

Compound 4, percent of the compound remaining: 86%
Compound 4: the middle estimate sits 32 percentage points below what was measured, outside the stated range (above it).
By their numbers in this assay, from the lowest: compound 3; then compound 1; then compound 4; then compound 2.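

In this assay, within the data shown here, this position, meta to a methoxy group and para to a fused ring, responds strongly to methoxy in place of hydrogen: the change is a number 46 percentage points higher from compound 3 to compound 4 (beyond the scatter), whereas the only earlier step, taken at another place on the same core, was a number 15 percentage points lower from compound 1 to compound 3 (beyond the scatter). The same position also carries the larger group of compound 2, and with hydrogen in place of 3-hydroxyphenyl on the saturated chain carbon bound to the oxygen, the change is a number 11 percentage points lower from compound 2 to compound 4 (beyond the scatter), so the plain methoxy already accounts for much of the high stability seen with that larger group. Nothing available explains why either step has the size it has.

Whether the gain is specific to methoxy remains open, since the compounds shown do not say how a fluorine, an amine or a longer chain such as ethoxy would behave at this position. They also leave open how much the hydroxyl on the 3-hydroxyphenyl group contributes, and whether an unsubstituted benzyl group would read the same.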